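Hydroxy for Cyano on the Aromatic Ring of Compound 2

The compounds below may be only part of what the source reports. "The series", "measured", "known", "first", "only" and "open" are said of these compounds alone.

Measured so far:
Compound 1, `C=CC[C@H]1C[C@]2([C@@H](C)Cc3ccc(OC)c(O)c3)OCOC2=CC1=O`: 80 nM
Compound 2, `C=CC[C@H]1C[C@]2([C@@H](C)Cc3cc(C#N)c(OC)cc3F)OCOC2=CC1=O`: 150 nM

Both compounds were tested in a functional assay on NCI-H460 cells (Homo sapiens) for antiproliferative activity, with a stated time of 72 h; on this read-out higher numbers stand for weaker inhibition and lower numbers for stronger inhibition. Among the compounds with values here, of the two numbers, the one for compound 2 sits at the top, but its distance to the number for compound 1 lies within the usual scatter of repeated measurements, so the two compounds cannot be separated on this evidence.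

Compound 3, `C=CC[C@H]1C[C@]2([C@@H](C)Cc3cc(O)c(OC)cc3F)OCOC2=CC1=O`, has not yet been measured. It differs from compound 2 in one place: hydroxy in place of cyano on an aromatic carbon. Within the data shown here, no step between two measured compounds is available for this change, so any expectation rests on the two values alone. Compound 1 also carries a hydroxy group ortho to a methoxy group and gives 80 nM in this assay, which suggests that compound 3 may settle in a similar region. Compound 3 is therefore expected to give 100 nM, within a range from 40 nM to 250 nM. The expected step of a 1.5-fold lower number from compound 2 to compound 3 (0.18 log units; within the scatter) is estimated to run toward stronger inhibition but to remain within the scatter.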

Compound 3, half-maximal inhibitory concentration: 33 nM
Compound 3: middle estimate off by 3.0-fold (0.48 log units), on the high side; measured number outside the range, below it.
By their numbers in this assay, from the lowest: compound 3; then compounds 1 and 2 (each within the scatter of the next).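

In this assay the aromatic position ortho to a methoxy group, meta to a large group and para to a fluoro group proves sensitive to its substituent: hydroxy in place of cyano gives a 4.5-fold lower number from compound 2 to compound 3 (0.66 log units; beyond the scatter) and so separates two compounds on a single change, which the two earlier numbers, lying within the scatter of each other, could not do. With the hydroxy group held in place, fluoro in place of hydrogen on an aromatic carbon also registers, as a 2.4-fold lower number from compound 1 to compound 3 (0.38 log units; beyond the scatter) shows, so the lowest number of the three comes from the ring that carries hydroxy, methoxy and fluoro groups together. Nothing available alongside these numbers speaks to why either step runs as it does.

The compounds shown leave open how an amine or a carboxylic acid at this position would compare with the hydroxy group. Also open, going by these compounds, is whether a chloro group would serve in place of the fluoro group, and whether the step seen for the fluoro group would carry over to a ring bearing cyano rather than hydroxy.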